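Extending the side chain on compound 2 with a methoxy group

The source may report more compounds than this note shows. Statements on the series, on what has been measured and on what is new or still open speak of the compounds shown alone.

Measured so far:
Compound 1, `CCCC(C)n1c(CC)nc2c(-c3ccc(OC)cc3C)ccnc21`: 0.8 nM
Compound 2, `CCc1nc2c(-c3ccc(Cl)cc3Cl)ccnc2n1[C@H](CC)C1CC1`: 0.2 nM

In an assay for binding affinity to Corticotropin releasing factor receptor (Rattus norvegicus) (a lower number here means a stronger inhibitor, a higher number a weaker inhibitor), compound 1 gives 0.8 nM and compound 2 gives 0.2 nM. Of the two, compound 2 has the lower number, and the gap between them lies beyond the usual scatter, so compound 2 stands as the stronger inhibitor of the pair in this assay.

Compound 3, `CCc1nc2c(-c3ccc(Cl)cc3Cl)ccnc2n1C(CCOC)C1CC1`, has not yet been measured. It differs from compound 2 in one place: 1-cyclopropyl-3-methoxypropyl in place of 1-cyclopropylpropyl on an aromatic nitrogen. The three-membered ring and the ethyl group on the shared core stay as they are; only the chain on the ring nitrogen grows by a methoxy group.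

Within the data shown here, no step between two measured compounds involves a change of this kind, so there is nothing to calibrate against. The expectation is that the step from compound 2 to compound 3 stays small, likely within the scatter or a slight move toward a weaker inhibitor, giving compound 3 an estimated 0.5 nM with a range from 0.15 nM to 2 nM, which corresponds to an expected step of a 2.5-fold higher number from compound 2 to compound 3 (0.40 log units; beyond the scatter).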

Compound 3, inhibition constant: 1.5 nM
For compound 3 the middle estimate is 3.0-fold (0.48 log units) below the measured one; the measured number falls inside the stated range.
By their numbers in this assay, from the lowest: compound 2; then compounds 1 and 3 (each within the scatter of the next).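

The nitrogen-bound chain of the shared core does not tolerate this extension without cost in this assay: 1-cyclopropyl-3-methoxypropyl in place of 1-cyclopropylpropyl gives a 7.5-fold higher number from compound 2 to compound 3 (0.88 log units; beyond the scatter), a move toward a weaker inhibitor. The swap also involves more than the added methoxy group, since the departing chain has one defined stereocentre and the entering chain has none, so this single step cannot separate those two differences. Nothing available here accounts for the size or direction of the step.

The compounds shown leave open whether an all-carbon chain of similar length, such as 1-cyclopropylbutyl, would give a comparable step. They also leave open how a terminal hydroxyl or amine on the same chain would compare with the methoxy group.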